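A few compounds are considered here, and "the series" means these few. Any claim that something is new, unique, unknown or untested is made for them only; others in the source may bear on it.

Compound 1 `CCOc1ccc(C(=O)/C=C/c2ccc(C)cc2)cc1`: 210 nM
Compound 2 `CCOc1ccc(C(=O)/C=C/c2ccc(Br)cc2)cc1`: 210 nM
Compound 3 `CCOc1ccc(C(=O)/C=C/c2ccc(Cl)cc2)cc1`: 210 nM

In an assay on isolated protein for inhibition of Amine oxidase [flavin-containing] B (Homo sapiens) (on this read-out lower numbers stand for stronger inhibition and higher numbers for weaker inhibition), compound 1 gives 210 nM and stands level with compounds 2 and 3, its nearest neighbour being compound 2 and its furthest compound 3, both within the scatter. The three measured steps, no change at the digits printed from compound 1 to compound 2 (within the scatter), no change at the digits printed from compound 1 to compound 3 (within the scatter) and no change at the digits printed from compound 2 to compound 3 (within the scatter), all exchange one substituent on the same aromatic carbon of the ring that does not carry the ethoxy group, and none of them moves the read-out beyond the scatter.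

Compound 4 `Cc1ccc(/C=C/C(=O)c2ccc(-n3ccnc3)cc2)cc1` differs from compound 1 elsewhere: 1H-imidazol-1-yl in place of ethoxy on an aromatic carbon. Going by the values given here, no measured step touches this position or this kind of exchange, so the measured steps give no direct guide; they show only that the shared core tolerates small substituent exchanges on the far ring. The change to compound 4 replaces an ethoxy with a five-membered aromatic ring bearing two hetero atoms, a larger alteration than any measured one, and the step of a 2.9-fold higher number from compound 1 to compound 4 (0.46 log units; beyond the scatter) in this assay is expected to be a modest loss with wide uncertainty. Compound 4 is therefore estimated at 600 nM, within a range from 150 nM to 2500 nM.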

Compound 4, half-maximal inhibitory concentration: 320 nM
For compound 4 the middle estimate is 1.9-fold (0.27 log units) above the measured one, and the stated range covers the measured number.
By their numbers in this assay, from the lowest: compounds 1, 2, 3 and 4 (each within the scatter of the next).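

In this assay, the exchange of ethoxy for 1H-imidazol-1-yl on an aromatic carbon, para to a large group, gives a 1.5-fold higher number from compound 1 to compound 4 (0.18 log units; within the scatter). The earlier steps shown here all lay on the ring that does not carry the ethoxy group, whereas this one shows that the read-out also stays within the scatter when the other end of the molecule is changed. Here a group of 3 heavy atoms with no ring gives way to one of 5 heavy atoms with a five-membered aromatic ring, and the ethoxy oxygen is lost, so at least in this one case neither that chain nor that oxygen is needed to hold the number, though no available evidence explains this result.

Going by these compounds, with a single exchange at this position, it remains open whether an amine, a carboxylic acid or a longer chain such as butoxy would leave the read-out equally undisturbed. On these data alone, the 1H-imidazol-1-yl group also appears here only with methyl on the far ring, so its pairing with bromo or chloro at that place remains open too.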